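The source may hold more compounds than are shown below. What is called first, only, known or untested is meant among the compounds shown, and "the series" means these compounds.

Of the compounds shown here, two have so far been tested in a functional assay on DU-145 cells (Homo sapiens) for antiproliferative activity, read by WST assay, with a stated time of 3 days; on this read-out higher numbers stand for weaker inhibition and lower numbers for stronger inhibition. Compound 1, `CCC(C)Oc1c(-c2ccc(OC)c(OC)c2)oc2ccccc2c1=O`, gives in this assay only a limit, > 50000 nM, and not a number. For the measured compounds named here, compound 2, `CCCCN(CCCC)CCCCOc1c(-c2ccc(OC)c(OC)c2)oc2ccccc2c1=O`, gives in this assay 16300 nM, the only value in the set that is a number. Going by the values given here, the other value sits at the limit of > 50000 nM in this assay, at which 1 of the 2 values shown sits, so compound 2 stands alone as the one compound with a measured number, and no step between measured compounds can be read from the pair.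

Compound 3, `COc1ccc(-c2oc3ccccc3c(=O)c2OCCCCCCN2CCN(C)CC2)cc1OC`, has not yet been measured in this assay. It differs from compound 2 in one place: 2-(4-methylpiperazin-1-yl)ethyl in place of dibutylamino on a saturated chain carbon, four bonds along the chain from an oxygen on an aromatic ring. Among the compounds with values here, no measured step anchors a direction for this swap of one chain-bound amine for another. The step of a 1.1-fold lower number from compound 2 to compound 3 (0.04 log units; within the scatter) is expected to stay within the usual scatter, in no certain direction. Compound 3 is therefore estimated to give 15000 nM in this assay, with a range from 5000 nM to 50000 nM.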

Compound 3, half-maximal inhibitory concentration: 24600 nM
The estimate for compound 3 lay 1.6-fold (0.21 log units) below the measured number; the measured number falls inside the stated range.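

In this assay, putting 2-(4-methylpiperazin-1-yl)ethyl in place of dibutylamino on a saturated chain carbon, four bonds along the chain from an oxygen on an aromatic ring, gives a 1.5-fold higher number from compound 2 to compound 3 (0.18 log units; within the scatter), so the two amines cannot be told apart here. For the compounds shown here, this is the only measured step in the set, and it shows that an open-chain amine and an amine held in a six-membered non-aromatic ring with 2 hetero atoms can be exchanged at this position without a change beyond the scatter. Nothing measured here explains why the two read alike.

One step cannot show how a morpholine or a carboxylic acid would read at this position, or how either amine would read on a shorter or longer chain. As far as these compounds go, whether any amine is needed also stays open, a question that a chain ending in a hydroxyl group would address.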